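The source may hold more compounds than are shown below. What is called first, only, known or untested is meant among the compounds shown, and "the series" means these compounds.

Working notes on the series.

Within the data shown here, in a functional assay on K562 cells (Homo sapiens) for inhibition, read by trypan blue exclusion, with a stated time of 72 h (a lower number here means a stronger inhibitor, a higher number a weaker inhibitor), compound 1 `Cn1c(=O)c(S(=O)(=O)c2ccc(F)cc2)cc2cnc(Nc3cnc4[nH]ccc4c3)nc21` gives 750 nM, the lower of the two numbers so far. Compound 2 `Cn1c(=O)c(S(=O)(=O)c2ccc(F)cc2)cc2cnc(Nc3ccc4cc[nH]c4c3)nc21` gives 10000 nM in this assay, and the step of a 13-fold higher number from compound 1 to compound 2 (1.12 log units; beyond the scatter) is the only measured one; it concerns the group on a nitrogen on an aromatic ring, not the side changed here.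

Compound 3 `Cn1c(=O)c(S(=O)(=O)c2ccc(Cl)cc2)cc2cnc(Nc3cnc4[nH]ccc4c3)nc21` differs from compound 1 by chloro in place of fluoro on an aromatic carbon on the (4-fluorophenyl)sulfonyl part. Among the measured compounds shown here, no measured step touches that part, so the single measured step gives no guide to the size or direction of this change, and no step beyond the scatter in this assay is expected.

For compound 3 the estimate is 650 nM, within 250 nM to 1800 nM, which corresponds to an expected step of a 1.2-fold lower number from compound 1 to compound 3 (0.06 log units; within the scatter).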

Compound 3, half-maximal inhibitory concentration: 5000 nM
Estimate against measurement, compound 3: 7.7-fold (0.89 log units) below, outside the stated range (above it).
By their numbers in this assay, from the lowest: compound 1; then compounds 3 and 2 (each within the scatter of the next).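

In this assay the (4-fluorophenyl)sulfonyl part is not a silent side of the molecule: chloro in place of fluoro, on an aromatic carbon para to a large group, gives a clear step (a 6.7-fold higher number from compound 1 to compound 3 (0.82 log units; beyond the scatter)). Among these compounds, the only earlier step concerned the group on a nitrogen on an aromatic ring, so it could not show that this other side also responds, and to the exchange of one halogen for another. Of the two halogens shown at this place, fluoro goes with the lower number, and no measurement at hand accounts for the step.

On these data alone, whether hydrogen, a methoxy group or a nitrile at this place would stay nearer compound 1 or compound 3 remains open. Also open, as far as these compounds go, is whether the same exchange would have a similar effect with the group of compound 2 in place of that of compound 1.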